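The compounds below may be only part of what the source reports. "The series", "measured", "known", "first", "only" and "open" are said of these compounds alone.

Compound 1 `N#Cc1c(-c2ccc(O)cc2)c(C#N)c(=O)n(/N=C/c2cn(-c3ccccc3)nc2-c2ccccc2)c1N` was tested in an ADME assay on NIH3T3 cells (Mus musculus) for cytotoxicity, read by MTT assay (a higher number here means a weaker inhibitor, a lower number a stronger inhibitor), where compound 1 gives 110 ug/mL. Among the compounds with values here, that is the only finished number in this set; the one other value recorded is a limit rather than a number. The limit belongs to compound 2 `N#Cc1c(-c2ccccc2[N+](=O)[O-])c(C#N)c(=O)n(/N=C/c2cn(-c3ccccc3)nc2-c2ccccc2)c1N`, which carries a 2-nitrophenyl in place of the 4-hydroxyphenyl on an aromatic carbon. In this assay compound 2 reaches a limit, > 200 ug/mL. Across that pair the change is an at least 1.8-fold higher number from compound 1 to compound 2 (0.25 log units; that floor lies within the scatter), so the true shift may be larger than the floor that can be stated; the limit of > 200 ug/mL in this assay, at which 1 of the 2 values shown sits, caps what the measurement can tell. Compound 3 `N#Cc1c(-c2ccc([N+](=O)[O-])cc2)c(C#N)c(=O)n(/N=C/c2cn(-c3ccccc3)nc2-c2ccccc2)c1N` has not yet been measured. It differs from compound 1 as follows: nitro in place of hydroxy on an aromatic carbon. Within the data shown here, the only measured step that bears on it is the one from compound 1 to compound 2, where a nitro also entered and the number rose to the limit. A similar move is expected here, so in this assay compound 3 is estimated at 180 ug/mL, with a range from 90 ug/mL to 320 ug/mL. The expected step is therefore a 1.6-fold higher number from compound 1 to compound 3 (0.21 log units; within the scatter).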

Compound 3, half-maximal inhibitory concentration: 84 ug/mL
The estimate for compound 3 lay 2.1-fold (0.33 log units) above the measured number, outside the stated range (below it).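

Compound 3 isolates a single exchange of hydroxy for nitro, para to a large group, and in this assay this gives a 1.3-fold lower number from compound 1 to compound 3 (0.12 log units; within the scatter), so compound 1 and compound 3 cannot be told apart here. The presence of a nitro group therefore does not by itself go with a rise in the number, a pattern that compound 2 alone might have suggested but that compound 3 goes against. Changing the 2-nitrophenyl to the 4-nitrophenyl gives a clearer separation, an at least 2.3-fold lower number from compound 2 to compound 3 (0.37 log units; beyond the scatter), and that figure is only a floor because of one bound on the measurement: the limit of > 200 ug/mL in this assay, at which 1 of the 3 values shown sits.

The compounds shown leave open how an amine, a carboxylic acid or a methoxy group at that same place on the ring would read in this assay. They also leave open how large the true gap between the two nitrophenyl compounds is, and whether a similar gap would appear with a group other than nitro.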